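Methyl on the Aromatic Ring of a Cytotoxic Enone Series

A few compounds are considered here, and "the series" means these few. Any claim that something is new, unique, unknown or untested is made for them only; others in the source may bear on it.

Of the compounds shown here, three have been tested in a functional assay on KB cells (Homo sapiens) for cytotoxicity; on this read-out higher numbers stand for an effect only at larger amounts of compound and lower numbers for an effect already at smaller amounts. Compound 1 `COC1=C(C)C(=O)/C(=C(O)/C=C/c2ccccc2C)C(=O)C1(C)C` gives 1.6 ug/mL. Compound 2 `COC1=C(C)C(=O)/C(=C(O)/C=C/c2c(C)cccc2C)C(=O)C1(C)C` gives 2.1 ug/mL. Compound 3 `CCC1=C(OC)C(CC)(CC)C(=O)C(C(=O)/C=C/c2ccccc2)=C1O` gives 1.2 ug/mL.

Compound 1 and compound 2 differ by one change, (methyl in place of hydrogen on an aromatic carbon). This change made a 1.3-fold higher number from compound 1 to compound 2 (0.12 log units; within the scatter), so the two values cannot be told apart by this measurement. Compound 3 carries a different core from compound 1; the difference between the two cores is not broken down here. Its value lies close to those of compound 1 and compound 2, and all three stand within the scatter of one another.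

Compound 4 `CCC1=C(OC)C(CC)(CC)C(=O)C(C(=O)/C=C/c2ccc(C)cc2)=C1O` has not yet been measured. It differs from compound 3 by methyl in place of hydrogen on an aromatic carbon. Among the measured compounds shown here, this is the same kind of change as the one from compound 1 to compound 2, but the surroundings are not identical: in the earlier pair the new methyl sits ortho to a large group and meta to a methyl group, whereas in compound 4 it sits para to a large group, on a ring that carries no other methyl.

Because the earlier step was a 1.3-fold higher number from compound 1 to compound 2 (0.12 log units; within the scatter), compound 4 is expected to show a step of a 1.3-fold higher number from compound 3 to compound 4 (0.10 log units; within the scatter) in this assay. On that basis the estimate for compound 4 is 1.5 ug/mL, most likely between 0.7 ug/mL and 3.2 ug/mL.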

Compound 4, concentration for half-maximal effect: 1 ug/mL
Compound 4: middle estimate off by 1.5-fold (0.18 log units), on the high side; measured number inside the range.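

In this assay, methyl in place of hydrogen on an aromatic carbon, para to a large group, gives a 1.2-fold lower number from compound 3 to compound 4 (0.08 log units; within the scatter), so the values of these two compounds cannot be told apart. Set beside the earlier step, the same change gives no readable difference on either core, and the two steps cannot be separated from each other: the same change on two cores in this assay, a 1.3-fold higher number (0.12 log units; within the scatter) from compound 1 to compound 2 and a 1.2-fold lower number (0.08 log units; within the scatter) from compound 3 to compound 4, 1.6-fold (0.20 log units) apart, within the scatter of two such steps. This suggests that, within what this measurement can resolve, adding this methyl leaves the read-out unchanged on both cores, but it does not show that the methyl has no effect at all, that the two steps truly agree in size or direction, or that its place on the ring is unimportant, as the methyl stands at a different place in each pair and steps this small could hide a slight real effect.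

The compounds shown leave open whether a group other than methyl on this ring, such as an amine, a carboxylic acid or a longer chain, would give a step large enough to read, and whether that step would carry from one core to the other. Also open, on these data alone, is what the core alone contributes, a question that compound 1 and compound 3, which differ in more than one place, cannot settle.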